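Piperidinyl to Methylpiperazinyl on a Shared Carbamate Core

A few compounds are considered here, and "the series" means these few. Any claim that something is new, unique, unknown or untested is made for them only; others in the source may bear on it.

Going by the values given here, compound 2 `CCCCCCCCCCCCCC[C@H](OCOC)[C@H](CN1CCCCC1)NC(=O)OC(C)(C)C` stands lowest of the two compounds measured so far in a functional assay on DLD-1 cells (Homo sapiens) for antiproliferative activity, read by sulforhodamine B assay, with a stated time of 48 h, tested at 10 uM (on this read-out lower numbers stand for less inhibition and higher numbers for more inhibition at the one concentration tested (going by the name of the read-out)), where compound 2 gives 43.7%. Among the compounds with values here, its nearest neighbour, compound 1 `CCCCCCCCCCCCCC[C@H](OCOC)[C@H](CN(C(C)C)C(C)C)NC(=O)OC(C)(C)C`, gives in this assay a value of 53.9%, and the step of a number 10.2 percentage points lower from compound 1 to compound 2 (beyond the scatter) is the only measured step in this set. Compound 3 `CCCCCCCCCCCCCC[C@H](OCOC)[C@H](CN1CCN(C)CC1)NC(=O)OC(C)(C)C` has not yet been measured. It differs from compound 2 in one place: 4-methylpiperazin-1-yl in place of piperidin-1-yl on a saturated chain carbon, two bonds along the chain from an amide-type nitrogen. Within the data shown here, no measured step replaces piperidin-1-yl by another ring, so the single known step, which replaced diisopropylamino by piperidin-1-yl and was modest in size, bears only loosely on the change at hand. Among the measured compounds shown here, with that step as the sole guide, a step of similar or smaller size is expected for compound 3 in this assay, and no direction can be read from the data with confidence. The estimate for compound 3 in this assay is therefore 40%, with a range from 18% to 62%, which corresponds to an expected step of a number 3.7 percentage points lower from compound 2 to compound 3 (within the scatter).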

Compound 3, a percentage reported as inhibition, at one concentration (the size of the read-out at that concentration, not a potency): 32%
Estimate against measurement, compound 3: 8 percentage points above; the range from low to high includes it.
By their numbers in this assay, from the lowest: compound 3; then compound 2; then compound 1.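

In this assay, the saturated chain carbon two bonds along the chain from an amide-type nitrogen now proves responsive to a change from one six-membered ring to another, and not only to the replacement of an open-chain amine by a ring: with 4-methylpiperazin-1-yl in place of piperidin-1-yl, the step is a number 11.7 percentage points lower from compound 2 to compound 3 (beyond the scatter). Among these three compounds, the numbers fall in order from diisopropylamino through piperidin-1-yl to 4-methylpiperazin-1-yl, and replacing diisopropylamino directly with 4-methylpiperazin-1-yl gives a larger step, a number 21.9 percentage points lower from compound 1 to compound 3 (beyond the scatter), so this single position spans a clear range of inhibition on the shared core. Nothing at hand accounts for the fall in inhibition from one ring to the other.

Still open, going by these compounds, is whether the lower number follows the second ring nitrogen or its methyl group, which a piperazin-1-yl ring with a hydrogen on that nitrogen, or a morpholine ring with an oxygen in its place, would help to separate. Equally open, on these data alone, is whether the order of the three groups would hold for a small open-chain amine such as dimethylamino, or for a pyrrolidine ring.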